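Side-Chain Exchange on the Amide and Cell Toxicity

This account rests on a few compounds, and the source may have more. Where it says the series, first, only, none or still open, it means among the compounds named here.

Two compounds have been measured in an ADME assay on MT4 cells (Homo sapiens) for cytotoxicity, read by MTT assay, with a stated time of 5 days; on this read-out lower numbers stand for higher toxicity in this test and higher numbers for lower toxicity in this test:
Compound 1, `C#CCNC(=O)/C=C/c1cnc(Nc2ccc(C#N)cc2)nc1Oc1c(C)cc(C#N)cc1C`, gives 141000 nM.
Compound 2, `Cc1cc(C#N)cc(C)c1Oc1nc(Nc2ccc(C#N)cc2)ncc1/C=C/C(=O)NCCOCCO`, gives 61800 nM.

Going by the values given here, compound 2 holds the lower of the two numbers, and the only measured step, a 2.3-fold lower number from compound 1 to compound 2 (0.36 log units; beyond the scatter), is the one that separates it from compound 1. That step, while beyond the scatter, was modest in size, and it concerns the same saturated chain bound to the amide-type nitrogen that is altered again in the next compound.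

Compound 3, `Cc1cc(C#N)cc(C)c1Oc1nc(Nc2ccc(C#N)cc2)ncc1/C=C/C(=O)NCCN1CCN(S(C)(=O)=O)CC1`, differs from compound 2 by 4-(methylsulfonyl)piperazin-1-yl in place of 2-hydroxyethoxy on a saturated chain carbon, two bonds along the chain from an amide-type nitrogen. Among the compounds with values here, the single measured step bears on this change only loosely: it shows that an exchange on this chain moved the number in this assay by a modest amount, but the group entering here is a different one, and no step with a ring of this kind has been measured. A step of at most modest size is therefore expected for compound 3, in either direction, and most probably none beyond the scatter: the expected step is a 1.1-fold higher number from compound 2 to compound 3 (0.05 log units; within the scatter). In this assay compound 3 is accordingly estimated at 70000 nM, within a range from 25000 nM to 200000 nM.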

Compound 3, half-maximal cytotoxic concentration: 5900 nM
Compound 3: middle estimate off by 12-fold (1.07 log units), on the high side; the measured number lies below the stated range.
By their numbers in this assay, from the lowest: compound 3; then compound 2; then compound 1.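

In this assay, a change on this saturated chain carbon, two bonds along the chain from an amide-type nitrogen, proves able to move the number much further than the earlier modest step of a 2.3-fold lower number from compound 1 to compound 2 (0.36 log units; beyond the scatter) had shown: 4-(methylsulfonyl)piperazin-1-yl in place of 2-hydroxyethoxy gives a 10-fold lower number from compound 2 to compound 3 (1.02 log units; beyond the scatter), a large step. Set against the ethynyl compound, (4-(methylsulfonyl)piperazin-1-yl)methyl in place of ethynyl gives a 24-fold lower number from compound 1 to compound 3 (1.38 log units; beyond the scatter), also large, so the ring-bearing side chain holds the lowest number of the three, which on this read-out stands for the highest toxicity in this test. Nothing available accounts for the size of this step.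

Open, from the compounds shown here alone, is which part of the entering group goes with the lower number, the piperazine ring or the methylsulfonyl group on it, since the two enter together; an unsubstituted piperazin-1-yl or a morpholin-4-yl group on the same chain would separate them. Also open, going by these compounds, is whether the step would keep its size if the ring stood on a longer chain.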